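The source may report more compounds than this note shows. Statements on the series, on what has been measured and on what is new or still open speak of the compounds shown alone.

Series notes. The shared core is an amide of a trimethoxyaniline; the three measured compounds differ only in the group on the carbonyl carbon. Compound 1 `COc1ccc(CN(C(=O)C2CC2)c2cc(OC)c(OC)c(OC)c2)cc1O` carries cyclopropyl and in a functional assay on KYSE-450 cells (Homo sapiens) for inhibition, read by MTT assay, with a stated time of 48 h (a lower number here means a stronger inhibitor, a higher number a weaker inhibitor), compound 1 gives 80 nM. Compound 2 `COc1ccc(CN(C(=O)CCCl)c2cc(OC)c(OC)c(OC)c2)cc1O` carries 2-chloroethyl, and in this assay compound 2 gives 110 nM. Compound 3 `COc1ccc(CN(C(=O)CBr)c2cc(OC)c(OC)c(OC)c2)cc1O` carries bromomethyl, and in this assay compound 3 gives 120 nM. On the numbers shown compound 3 has the highest of the three values, but a 1.5-fold higher number from compound 1 to compound 3 (0.18 log units; within the scatter) and a 1.1-fold higher number from compound 2 to compound 3 (0.04 log units; within the scatter) are both within the scatter, as is a 1.4-fold higher number from compound 1 to compound 2 (0.14 log units; within the scatter), so the three cannot be told apart.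

Compound 4 `C=CC(=O)N(Cc1ccc(OC)c(O)c1)c1cc(OC)c(OC)c(OC)c1` is not yet measured. Its change from compound 3 is vinyl in place of bromomethyl on a carbonyl carbon. For the measured compounds named here, the steps that bear on it are the swaps already seen on the carbonyl carbon, all within the scatter, so no step beyond the scatter is expected in this assay. Compound 4 is therefore estimated at 100 nM, with a range of 45 nM to 250 nM, which means an expected step of a 1.2-fold lower number from compound 3 to compound 4 (0.08 log units; within the scatter).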

Compound 4, half-maximal inhibitory concentration: 160 nM
For compound 4 the middle estimate is 1.6-fold (0.20 log units) below the measured one, within the range that was stated.
By their numbers in this assay, from the lowest: compounds 1, 2, 3 and 4 (each within the scatter of the next).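

In this assay the swap to vinyl on the carbonyl carbon stays within the scatter against all three earlier groups (a 1.3-fold higher number from compound 3 to compound 4 (0.12 log units; within the scatter); a 1.5-fold higher number from compound 2 to compound 4 (0.16 log units; within the scatter); a 2.0-fold higher number from compound 1 to compound 4 (0.30 log units; within the scatter)). Until now every group at this position held either a ring or a halogen, whereas vinyl holds neither and brings a double bond outside aromatic rings, so the position now also covers a small open-chain group without halogen, with no step beyond the scatter. No data shown here bear on why these values lie so close together.

From the compounds shown here alone, whether the flat picture survives a larger change at this position, such as an amine, a carboxylic acid or a longer chain on the carbonyl carbon, remains open. Also open, going by these compounds, is whether the four compounds stay this close outside this assay.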